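The source may report more compounds than this note shows. Statements on the series, on what has been measured and on what is new or still open speak of the compounds shown alone.

Compound 1 `C=CCNC(=O)/C(C)=C(\C)c1ccc(Br)cc1` gives 33.7 mg/kg in a functional assay on the whole organism (strain Icem-CET (SPF Caw)) for inhibition, with Mus musculus as the target, with a stated time of 30 min; a lower number here means that less compound is needed, a higher number that more compound is needed for the effect. Compound 2 `C#CCNC(=O)/C(C)=C(\C)c1ccc(C)cc1` stands at the higher of the two numbers, with 86.4 mg/kg in this assay, a gap from compound 1 that lies beyond the usual scatter. Compound 3 `C=CCNC(=O)/C(C)=C(\C)c1ccc(C)cc1` differs from compound 2 by vinyl in place of ethynyl on a saturated chain carbon bound to an amide-type nitrogen. For the measured compounds named here, no measured pair isolates this change, so its effect is open. The expected step from compound 2 to compound 3 is a modest move toward a lower number, a 1.6-fold lower number from compound 2 to compound 3 (0.20 log units; within the scatter), close to the edge of the scatter. Compound 3 is therefore estimated at 55 mg/kg, within a range from 28 mg/kg to 110 mg/kg.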

Compound 3, dose for half-maximal effect: 78 mg/kg
Beside the measured number, compound 3's estimate is 1.4-fold (0.15 log units) below it; the measured number falls inside the stated range.
By their numbers in this assay, from the lowest: compound 1; then compounds 3 and 2 (each within the scatter of the next).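

In this assay, vinyl in place of ethynyl on a saturated chain carbon bound to an amide-type nitrogen gives no separation (a 1.1-fold lower number from compound 2 to compound 3 (0.04 log units; within the scatter)), so allyl and propargyl cannot be told apart with methyl on the aromatic carbon. For the compounds shown here, with the allyl chain held constant, methyl in place of bromo on an aromatic carbon gives the first single-place step that clears the scatter (a 2.3-fold higher number from compound 1 to compound 3 (0.36 log units; beyond the scatter)). Nothing at hand bears on the cause of either step. The compounds shown leave open whether a longer chain on the amide nitrogen would separate from allyl and propargyl. They also leave open how chloro or methoxy on that aromatic carbon would compare with bromo.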